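Replacing 4-fluorophenyl with 1H-indol-3-yl

The compounds below may be only part of what the source reports. "The series", "measured", "known", "first", "only" and "open" are said of these compounds alone.

Compound 1 `COc1cc(-c2cc3nccc(-c4cc(OC)c(OC)c(OC)c4)n3n2)cc(OC)c1OC`: > 10000 nM (a limit)
Compound 2 `COc1cc(-c2ccnc3cc(-c4ccc(F)cc4)nn23)cc(OC)c1OC`: 5840 nM

Going by the values given here, in a functional assay on HeLa cells (Homo sapiens) for inhibition, read by CCK-8 assay, with a stated time of 48 h (on this read-out lower numbers stand for stronger inhibition and higher numbers for weaker inhibition), compound 2 gives 5840 nM, the only true number so far. The entry for compound 1 is a limit of the assay and not a number. Compound 3 `COc1cc(-c2ccnc3cc(-c4c[nH]c5ccccc45)nn23)cc(OC)c1OC` has 1H-indol-3-yl in place of 4-fluorophenyl on an aromatic carbon. Among the compounds with values here, no measured step exists to guide the forecast, so the expectation is tentative: a sizeable move towards stronger inhibition in this assay. The expected change is a 15-fold lower number from compound 2 to compound 3 (1.16 log units; beyond the scatter). The estimated value for compound 3 is 400 nM, with an expected range from 30 nM to 5000 nM.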

Compound 3, half-maximal inhibitory concentration: 195 nM
Beside the measured number, compound 3's estimate is 2.1-fold (0.31 log units) above it; the measured number falls inside the stated range.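

In this assay, the group on this aromatic carbon of the five-membered ring clearly matters: 1H-indol-3-yl in place of 4-fluorophenyl gives a 30-fold lower number from compound 2 to compound 3 (1.48 log units; beyond the scatter). Going by these compounds alone, this is the first step that can be read, and it shows that this position responds strongly to a change of group. Nothing measured here explains the size of this step.

On these data alone, it remains open whether the hydrogen on the indole nitrogen matters, which 1-methyl-1H-indol-3-yl could test. As far as these compounds go, how naphthalen-2-yl, which has two fused rings of carbon only, or a simple amine would fare at this position is also open.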